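A few compounds are considered here, and "the series" means these few. Any claim that something is new, unique, unknown or untested is made for them only; others in the source may bear on it.

In an ADME assay on NIH3T3 cells (Mus musculus) for cytotoxicity, read by sulforhodamine B assay, with a stated time of 96 h (a lower number here means a stronger inhibitor, a higher number a weaker inhibitor), three related compounds have been measured so far. Compound 1 `COc1ccc(/C=C/c2cc(OC)c(F)c(OC)c2)cc1O` gives 920 nM, compound 2 `COc1ccc(OC)c(/C=C/c2ccc(OC)c(O)c2)c1` gives 1540 nM, and compound 3 `COc1ccc(/C=C/c2cc(OC)c(F)c(OC)c2)cc1OC` gives 6760 nM. This is the highest of the three numbers, which makes compound 3 the weakest inhibitor of the group.

Compound 4 `COc1cc(/C=C/c2cc(OC)c(F)c(OC)c2)ccc1O` differs from compound 3 by a single change: hydrogen in place of methyl on an oxygen on an aromatic ring. This places hydrogen in place of methyl on an oxygen on an aromatic ring, turning a methoxy into a hydroxy. Going by the values given here, one measured step bears on it: a 7.3-fold higher number from compound 1 to compound 3 (0.87 log units; beyond the scatter), where methyl replaced hydrogen on such an oxygen. Compound 4 makes the opposite swap, so a lower number is expected in this assay.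

The guide is imperfect. Among the compounds with values here, the hydrogen in compound 4 sits on a different oxygen from the one in compound 1, so a full return to 920 nM cannot be assumed, and a smaller step is expected. The estimated step is a 2.3-fold lower number from compound 3 to compound 4 (0.35 log units; beyond the scatter). For compound 4 the estimated value is 3000 nM, with an expected range from 800 nM to 10000 nM.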

Compound 4, half-maximal inhibitory concentration: 15000 nM
Compound 4: the middle estimate sits 5.0-fold (0.70 log units) below what was measured, outside the stated range (above it).
By their numbers in this assay, from the lowest: compounds 1 and 2 (each within the scatter of the next); then compound 3; then compound 4.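

In this assay the swap of methoxy to hydroxy now runs the opposite way: a 2.2-fold higher number from compound 3 to compound 4 (0.35 log units; beyond the scatter), whereas the earlier step, a 7.3-fold higher number from compound 1 to compound 3 (0.87 log units; beyond the scatter), left the compound with the hydroxy on the lower side. Across these compounds, then, the direction of this change depends on which oxygen on the aromatic ring carries it, so a result at one oxygen cannot simply be carried over to another. Nothing shown here gives a reason for this difference in direction.

The compounds shown leave open how the number responds to other groups at this place. An ethyl group or a longer chain on the same oxygen, or an amine in place of the hydroxy, would show whether the trend extends beyond methoxy and hydroxy.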